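Chloro Substitution Repeated on a Nitro-Bearing Analogue

The source may report more compounds than this note shows. Statements on the series, on what has been measured and on what is new or still open speak of the compounds shown alone.

Measured compounds in a functional assay on the whole organism (artery, strain albino) with Rattus norvegicus as the target, with a stated time of 180 min, at a dose of 10 mg/kg by the oral route; on this read-out lower numbers stand for less inhibition and higher numbers for more inhibition at the one dose given (going by the name of the read-out):
compound 1 `COc1ccc(C2N=C(SCc3ccccc3)NC(C)=C2C(=O)Nc2ccc(Br)cc2)cc1` gives 10.3%
compound 2 `COc1ccc(C2N=C(SCc3ccccc3Cl)NC(C)=C2C(=O)Nc2ccc(Br)cc2)cc1` gives 11.3%
compound 3 `CC1=C(C(=O)Nc2ccc([N+](=O)[O-])cc2)C(c2ccc(Br)cc2)N=C(SCc2ccccc2)N1` gives 19.6%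

Compound 1 and compound 2 share one core, and compound 2 differs from compound 1 by chloro in place of hydrogen on an aromatic carbon. The step between them, a number 1 percentage points higher from compound 1 to compound 2 (within the scatter), is too small to be told from scatter, so the two values say nothing about a direction. Compound 3 carries a different core; the difference between the two cores is not broken down here. Its value stands nearest to compound 2 and furthest from compound 1, yet both gaps lie within the scatter, so no order among the three can be stated.

Compound 4 `CC1=C(C(=O)Nc2ccc([N+](=O)[O-])cc2)C(c2ccc(Br)cc2)N=C(SCc2ccccc2Cl)N1` has not yet been measured in this assay. It differs from compound 3 by chloro in place of hydrogen on an aromatic carbon. The place of this change is described in the same words as for the change from compound 1 to compound 2, so it is the same change made on another core. For the measured compounds named here, since the one example of this change gave a number 1 percentage points higher from compound 1 to compound 2 (within the scatter), compound 4 is expected to stay close to compound 3, with a step of a number 1.4 percentage points higher from compound 3 to compound 4 (within the scatter). Compound 4 is estimated at 21%, most likely between 8% and 34%.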

Compound 4, a percentage reported as inhibition, in the whole organism at one dose (the size of the read-out at that dose, not a potency): 11.3%
For compound 4 the middle estimate is 9.7 percentage points above the measured one; the measured number falls inside the stated range.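

In this assay, exchanging benzyl for 2-chlorobenzyl on the core of compound 3 gave a number 8.3 percentage points lower from compound 3 to compound 4 (within the scatter). Set beside the earlier example of the same change, the two steps do not differ by more than repeated measurement would allow: the same change on two cores in this assay, a number 1 percentage points higher (within the scatter) from compound 1 to compound 2 and a number 8.3 percentage points lower (within the scatter) from compound 3 to compound 4, 9.3 percentage points apart, within the scatter of two such steps. This gives no sign that the change acts differently on the two cores, yet it does not show that the change acts alike on both, as neither step stands clear of scatter and no effect of the chloro group is shown on either core.

The compounds shown leave open whether a fluoro or methyl group on the same benzyl ring, or a longer chain in place of benzyl, would give a value set apart from these. They also leave open what an amine or a carboxylic acid on the aryl group of the amide would do in this assay.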